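Five-membered heteroaryl swaps on a nitrocatechol chalcone scaffold

The compounds below may be only part of what the source reports. "The series", "measured", "known", "first", "only" and "open" are said of these compounds alone.

Compound 1, `O=C(/C=C/c1ccsc1)c1cc(O)c(O)c([N+](=O)[O-])c1`: 41400 nM
Compound 2, `O=C(/C=C/c1ccoc1)c1cc(O)c(O)c([N+](=O)[O-])c1`: 52900 nM

In an assay on isolated protein for inhibition of Amine oxidase [flavin-containing] A (Homo sapiens), read by fluorescence (a higher number here means a weaker inhibitor, a lower number a stronger inhibitor), compound 2 gives 52900 nM, the highest of the two numbers, with compound 1 nearest at 41400 nM; the step of a 1.3-fold higher number from compound 1 to compound 2 (0.11 log units; within the scatter) lies within the scatter. Compound 3, `O=C(/C=C/c1nccs1)c1cc(O)c(O)c([N+](=O)[O-])c1`, differs from compound 2 by 1,3-thiazol-2-yl in place of furan-3-yl on a double-bonded chain carbon bound to a double-bonded chain carbon. Among the measured compounds shown here, the one measured step bearing on this, a 1.3-fold higher number from compound 1 to compound 2 (0.11 log units; within the scatter), was small, so no shift beyond the scatter is expected in this assay. Compound 3 is therefore estimated at 45000 nM, between 15000 nM and 150000 nM, a step of a 1.2-fold lower number from compound 2 to compound 3 (0.07 log units; within the scatter) that is expected to stay within the scatter.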

Compound 3, half-maximal inhibitory concentration: 69600 nM
For compound 3 the middle estimate is 1.5-fold (0.19 log units) below the measured one; the measured number falls inside the stated range.
By their numbers in this assay, from the lowest: compounds 1, 2 and 3 (each within the scatter of the next).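

In this assay, 1,3-thiazol-2-yl on a double-bonded chain carbon bound to a double-bonded chain carbon gives a 1.3-fold higher number from compound 2 to compound 3 (0.12 log units; within the scatter) against furan-3-yl, and a 1.7-fold higher number from compound 1 to compound 3 (0.23 log units; within the scatter) against thiophen-3-yl. A five-membered aromatic ring with 2 hetero atoms thus stays within the scatter of both rings with 1 hetero atom, so this change does not clearly separate any of the three compounds. Nothing available here explains these small differences.

As far as these compounds go, it remains open whether a phenyl ring, a pyridin-2-yl ring or a ring carrying an amine at this place would move the number beyond the scatter.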